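The source may hold more compounds than are shown below. What is called first, only, known or untested is meant among the compounds shown, and "the series" means these compounds.

Working notes on the series.

Three compounds have numbers in an assay on CHO cells for displacement of a labelled ligand from adenosine receptor A1 (Homo sapiens), tested at 10 uM; on this read-out higher numbers stand for more inhibition at the one concentration tested (going by the name of the read-out) and lower numbers for less inhibition. Compound 1 `COc1ccc(Cl)cc1CNc1ncnc2c1ncn2[C@@H]1OC[C@@](O)(CO)[C@H]1O` gives 13% in this assay. Compound 3 `CNC(=O)OC[C@@]1(O)CO[C@@H](n2cnc3c(N)ncnc32)[C@@H]1O` gives 12%, and compound 2 `Nc1ncnc2c1ncn2[C@@H]1OC[C@H](CO)[C@H]1O` gives 6%. Compound 1 sits at the top of the three numbers, but its gap to compound 3 and its gap to compound 2 both lie within the usual scatter, so the three are not separated by this assay; all are small displacements at the single concentration tested.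

Compound 4 `OC[C@]1(O)CO[C@@H](n2cnc3c(NCc4cccc(Cl)c4)ncnc32)[C@@H]1O` has not yet been measured in this assay. Compared with compound 1, the change is hydrogen in place of methoxy on an aromatic carbon. Among the measured compounds shown here, no pair of measured compounds differing in one place is available, so the step cannot be anchored on a comparison. Given that compound 1 gives 13% and the whole set stays low, the step from compound 1 to compound 4 is expected to be a number 4 percentage points lower from compound 1 to compound 4 (within the scatter), that is, none beyond the scatter. Compound 4 is estimated at 9%, with a range from 0% to 22%.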

Compound 4, a percentage reported as inhibition, at one concentration (the size of the read-out at that concentration, not a potency): 19%
For compound 4 the middle estimate is 10 percentage points below the measured one; low and high end bracket the measured number.
By their numbers in this assay, from the lowest: compounds 2, 3, 1 and 4 (each within the scatter of the next, the first and the last beyond it).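

In this assay, hydrogen in place of methoxy on this aromatic carbon, ortho to a large group and para to a chloro group, gives a number 6 percentage points higher from compound 1 to compound 4 (within the scatter). Among the compounds shown here, this is the first comparison between compounds that differ in one place, and it shows that the methoxy can be removed from this position without a change that stands clear of the scatter. Nothing measured on these compounds accounts for the direction of the step.

The compounds shown leave open whether a different group on this aromatic carbon, such as an amine, a carboxylic acid or a longer alkoxy chain, would move the number beyond the scatter. Also open, on these data alone, is how compound 1 and compound 4 compare in potency, since a percentage at one concentration does not give one.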